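Replacing 1,3-benzothiazol-2-yl with 3-carboxyphenyl on the amide nitrogen

The source may hold more compounds than are shown below. What is called first, only, known or untested is meant among the compounds shown, and "the series" means these compounds.

Measured in a functional assay on CLL cells (Homo sapiens) for cytotoxicity, read by MTT assay, with a stated time of 48 h; on this read-out higher numbers stand for an effect only at larger amounts of compound and lower numbers for an effect already at smaller amounts:
- compound 1 `C=C(CC)C(=O)c1ccc(OCC(=O)Nc2ccc(C(=O)O)cn2)c(Cl)c1Cl`: 14900 nM
- compound 2 `C=C(CC)C(=O)c1ccc(OCC(=O)Nc2nc3ccccc3s2)c(Cl)c1Cl`: 1500 nM

Compound 2 has the lower of these two numbers, so it acts at smaller amounts. Compound 3 `C=C(CC)C(=O)c1ccc(OCC(=O)Nc2cccc(C(=O)O)c2)c(Cl)c1Cl` keeps the shared core and changes one group: 3-carboxyphenyl in place of 1,3-benzothiazol-2-yl on an amide-type nitrogen. Among the measured compounds shown here, one measured step bears on this change: a 9.9-fold lower number from compound 1 to compound 2 (1.00 log units; beyond the scatter) when 1,3-benzothiazol-2-yl replaces 5-carboxypyridin-2-yl. Both 3-carboxyphenyl and that 5-carboxypyridin-2-yl group carry a carboxy group, so that step is expected to run largely in reverse. For the measured compounds named here, no measured compound holds 3-carboxyphenyl itself, so the size remains uncertain. In this assay the expected change points towards a higher number: an 8.0-fold higher number from compound 2 to compound 3 (0.90 log units; beyond the scatter) is estimated. For compound 3 the estimated value is 12000 nM with an expected range from 4000 nM to 35000 nM overall.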

Compound 3, half-maximal effective concentration: 20600 nM
For compound 3 the middle estimate is 1.7-fold (0.23 log units) below the measured one; low and high end bracket the measured number.
By their numbers in this assay, from the lowest: compound 2; then compounds 1 and 3 (each within the scatter of the next).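

In this assay, putting 3-carboxyphenyl in place of 1,3-benzothiazol-2-yl on the amide-type nitrogen gives a 14-fold higher number from compound 2 to compound 3 (1.14 log units; beyond the scatter) and confirms, with a group other than 5-carboxypyridin-2-yl, that this position responds strongly to the group it carries. Exchanging the two carboxy-bearing groups gives a 1.4-fold higher number from compound 1 to compound 3 (0.14 log units; within the scatter) and so leaves the number essentially in place, which means that among these three compounds the two with a carboxy group stand together, well apart from compound 2, and none goes against this. Nothing available here explains this difference.

As far as these compounds go, what stays open is whether the carboxy group or the loss of the 1,3-benzothiazol-2-yl ring system drives the step. A plain phenyl group, or a 1,3-benzothiazol-2-yl group carrying a carboxylic acid, would separate the two.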